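This account rests on a few compounds, and the source may have more. Where it says the series, first, only, none or still open, it means among the compounds named here.

Three compounds of the series have numbers in an assay for inhibition of Indoleamine 2,3-dioxygenase 1 (Homo sapiens), read by fluorescence, with a stated time of 1 h; a lower number here means a stronger inhibitor, a higher number a weaker inhibitor. Compound 1 `NS(=O)(=O)NCCSc1nonc1/C(=N/O)Nc1ccc(F)c(Br)c1` gives 130 nM. Compound 2 `NS(=O)(=O)CC(=O)NCCSc1nonc1/C(=N/O)Nc1ccc(F)c(C(F)F)c1` gives 73 nM, and compound 3 `N#Cc1cc(N/C(=N\O)c2nonc2SCCNC(=O)CS(N)(=O)=O)ccc1F` gives 150 nM. Compound 1 stands second highest of the three numbers: compound 3 is nearest and compound 2 furthest, and both gaps lie within the usual scatter, so no order among the three can be read from them. For the measured compounds named here, the only single change measured so far is a 2.1-fold higher number from compound 2 to compound 3 (0.31 log units; beyond the scatter); it concerns a different part of the molecule from the linker that joins the shared core to the sulfamoylamino group.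

Compound 4 `NS(=O)(=O)NCCOc1nonc1/C(=N/O)Nc1ccc(F)c(Br)c1` differs from compound 1 in exactly that linker: 2-(sulfamoylamino)ethoxy in place of (2-(sulfamoylamino)ethyl)sulfanyl on an aromatic carbon. Going by the values given here, no measured pair touches this part of the molecule, so there is no step to lean on and the change has to be treated as untested. The working expectation is a step not beyond the scatter, a 1.5-fold higher number from compound 1 to compound 4 (0.19 log units; within the scatter), leaning toward a slightly higher number. For compound 4 the estimate in this assay is 200 nM, with a range from 70 nM to 600 nM.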

Compound 4, half-maximal inhibitory concentration: 150 nM
Beside the measured number, compound 4's estimate is 1.3-fold (0.12 log units) above it; the measured number falls inside the stated range.
By their numbers in this assay, from the lowest: compounds 2, 1, 3 and 4 (each within the scatter of the next, the first and the last beyond it).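

For the compounds shown here, the exchange of (2-(sulfamoylamino)ethyl)sulfanyl for 2-(sulfamoylamino)ethoxy gives the first measured pair at this position, and a 1.2-fold higher number from compound 1 to compound 4 (0.06 log units; within the scatter) in this assay places the change within the scatter. For this pair, sulfur and oxygen as the atom attached to the aromatic carbon cannot be told apart by this read-out, so the linker position accepts this exchange without a step beyond the scatter. No measurement here offers an explanation for the two linkers reading alike.

On these data alone, this rests on one pair with the aromatic substitution of compound 1, and whether the exchange reads the same with the side chain or aromatic groups of compound 2 and compound 3 remains open. Also open, as far as these compounds go, is how an amine at the same attachment point, or a longer chain carrying the sulfamoylamino group, would read.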